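The source may report more compounds than this note shows. Statements on the series, on what has been measured and on what is new or still open speak of the compounds shown alone.

Compound 1 (`CCn1ccnc1/C=C/C(=O)/C=C/c1coc2ccccc2c1=O`) and compound 2 (`CCCn1ccnc1/C=C/C(=O)/C=C/c1coc2ccccc2c1=O`) share one core and differ only in the length of one saturated chain. In a functional assay on LNCaP cells (Homo sapiens) for inhibition, read by WST assay, with a stated time of 3 days (on this read-out lower numbers stand for stronger inhibition and higher numbers for weaker inhibition), compound 1 gives 1000 nM and compound 2 gives 2100 nM as its measured value. Among the compounds with values here, compound 2 therefore holds the higher of the only two numbers available, which makes it the weaker inhibitor of the pair. The next compound, compound 3 (`CCCCCn1ccnc1/C=C/C(=O)/C=C/c1coc2ccccc2c1=O`), lengthens the same chain from propyl to pentyl. The change is ethyl in place of hydrogen on a saturated chain carbon, three bonds along the chain from an aromatic nitrogen and nothing else in the structure differs. Within the data shown here, only one measured step bears on it: a 2.1-fold higher number from compound 1 to compound 2 (0.32 log units; beyond the scatter) when methyl replaces hydrogen on that chain. One step makes a thin trend, and no data yet show whether it continues. Even so, this change extends the same chain, so a further rise in the number in this assay is expected, of similar or somewhat smaller size. The expected change is a 1.7-fold higher number from compound 2 to compound 3 (0.22 log units; within the scatter) in this estimate. Compound 3 is estimated at 3500 nM with an expected range of 1500 nM to 8000 nM for its measurement.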

Compound 3, half-maximal inhibitory concentration: 1800 nM
Beside the measured number, compound 3's estimate is 1.9-fold (0.29 log units) above it; low and high end bracket the measured number.
By their numbers in this assay, from the lowest: compounds 1, 3 and 2 (each within the scatter of the next, the first and the last beyond it).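

In this assay, lengthening the chain from propyl to pentyl gives a 1.2-fold lower number from compound 2 to compound 3 (0.07 log units; within the scatter) and so does not extend the rise seen in the first step; a longer chain at this position does not simply bring a higher number. Going from ethyl to pentyl gives a 1.8-fold higher number from compound 1 to compound 3 (0.26 log units; within the scatter), which leaves the longest chain shown inseparable from the shortest, even though the ethyl and propyl compounds differ by more than the scatter, so the three compounds show no steady trend with chain length and the position tolerates a pentyl chain about as well as an ethyl one. Nothing available explains this behaviour of the numbers.

From the compounds shown here alone, what a butyl chain would give remains open, as does whether a chain longer than pentyl, such as octyl, would stay in the same range of numbers. Also open, going by these compounds, is how this position would respond to something other than a plain saturated chain, for example a chain ending in an amine or a carboxylic acid.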